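A few compounds are considered here, and "the series" means these few. Any claim that something is new, unique, unknown or untested is made for them only; others in the source may bear on it.

Compound 1 `NCCn1ncc2c(NCc3ccccc3[N+](=O)[O-])cc(C(F)(F)F)cc21` is one of three compounds tested in an assay for inhibition of Tryptophan 2,3-dioxygenase (Homo sapiens), with stated times of 10 min and 60 min, tested at 100 uM (a higher number here means a stronger effect of the compound at the concentration tested, a lower number a weaker effect), where compound 1 gives 29%. That places it second highest of the three. Compound 3 `OC1CCCC(Nc2cccc(CNc3cc(C(F)(F)F)cc4[nH]ncc34)c2)C1` gives 23%, a number within the usual scatter of the value of compound 1, so the two cannot be told apart. Compound 2 `O=[N+]([O-])c1ccccc1CNc1cc(Br)cc2[nH]ncc12` gives 64%, which lies well beyond the scatter above compound 1. Compound 4 `CC(C)n1ncc2c(NCc3ccccc3[N+](=O)[O-])cc(C(F)(F)F)cc21` has not been measured yet. It differs from compound 1 in one place: isopropyl in place of 2-aminoethyl on an aromatic nitrogen. Within the data shown here, no measured pair here shows what isopropyl in place of 2-aminoethyl does, so no known step can be leaned on. The expected step is a number 1 percentage points higher from compound 1 to compound 4 (within the scatter), which need not exceed the scatter. Compound 4 is therefore estimated at 30%, between 10% and 55%.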

Compound 4, a percentage reported as inhibition, at one concentration (the size of the read-out at that concentration, not a potency): 32%
Compound 4: the middle estimate sits 2 percentage points below what was measured; the measured number falls inside the stated range.
By their numbers in this assay, from the lowest: compounds 3, 1 and 4 (each within the scatter of the next); then compound 2.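

In this assay the change from 2-aminoethyl to isopropyl on the aromatic nitrogen gives a number 3 percentage points higher from compound 1 to compound 4 (within the scatter) and so leaves the read-out indistinguishable. This position therefore accepts either chain without a readable difference, even though isopropyl has none of the hydrogen-bond donors and acceptors counted for 2-aminoethyl. No measured evidence here accounts for this result. As far as these compounds go, whether a carboxylic acid or a longer chain on this nitrogen would also leave the number unchanged remains open. So does how a bare hydrogen there would compare, with the rest of compound 1 kept the same.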